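Methoxy added to the phenyl of compound 3

A few compounds are considered here, and "the series" means these few. Any claim that something is new, unique, unknown or untested is made for them only; others in the source may bear on it.

compound 1 `Cn1cc(C2CC(c3ccccc3)=NN2C(=O)c2cccnc2)c2ccccc21` gives 4630 nM
compound 2 `Cn1cc(C2CC(c3ccccc3)=NN2C(=O)c2cccnc2)c2cc(Br)ccc21` gives 2520 nM
compound 3 `COc1ccc2c(c1)c(C1CC(c3ccccc3)=NN1C(=O)c1cccnc1)cn2C` gives 5110 nM

In a functional assay on HepG2 cells (Homo sapiens) for inhibition, read by MTT assay, with a stated time of 48 h (on this read-out higher numbers stand for weaker inhibition of growth and lower numbers for stronger inhibition of growth), compound 3 sits level with compound 1 within the scatter, and its one gap beyond the scatter is a 2.0-fold higher number from compound 2 to compound 3 (0.31 log units; beyond the scatter) as a modest step. Next comes compound 4 `COc1cccc(C2=NN(C(=O)c3cccnc3)C(c3cn(C)c4ccc(OC)cc34)C2)c1` with methoxy in place of hydrogen on an aromatic carbon as the change, methoxy in place of hydrogen on an aromatic carbon. Going by the values given here, the closest precedent is a 1.1-fold higher number from compound 1 to compound 3 (0.04 log units; within the scatter) for the same exchange, at another place in the molecule. The bromo exchange gave a 1.8-fold lower number from compound 1 to compound 2 (0.26 log units; within the scatter) as its step. Among the compounds with values here, no measured step touches the phenyl, so no step beyond the scatter is expected in this assay and no direction is called. The estimated step is a 1.1-fold lower number from compound 3 to compound 4 (0.06 log units; within the scatter) on this reasoning. For compound 4 the estimated value is 4500 nM with an expected range from 2200 nM to 9000 nM as a working figure.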

Compound 4, concentration for 50% growth inhibition: 910 nM
For compound 4 the middle estimate is 4.9-fold (0.69 log units) above the measured one; measured number outside the range, below it.
By their numbers in this assay, from the lowest: compound 4; then compounds 2, 1 and 3 (each within the scatter of the next, the first and the last beyond it).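

In this assay, going by these compounds alone, the phenyl responds to substitution: phenyl to 3-methoxyphenyl gives a 5.6-fold lower number from compound 3 to compound 4 (0.75 log units; beyond the scatter) as the first measured step at this ring. The same exchange at another place gave a 1.1-fold higher number from compound 1 to compound 3 (0.04 log units; within the scatter) and stayed within the scatter, so across these two pairs the outcome of adding methoxy depends on where it sits. No measurement at hand accounts for the larger step.

Still open, on these data alone, is whether the step is specific to methoxy or would also appear with a hydroxyl, an amine or a longer alkoxy chain on the phenyl. Other places on that ring also remain open.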